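Fluoro added to compound 1: working notes

The source may hold more compounds than are shown below. What is called first, only, known or untested is meant among the compounds shown, and "the series" means these compounds.

Measured in a functional assay on PBMC cells (Homo sapiens) for inhibition, read by HTRF, with stated times of 15 min and 24 h; on this read-out higher numbers stand for weaker inhibition and lower numbers for stronger inhibition:
compound 1 `O=C(Nc1ccc2c(c1)B(O)OC2)c1ccccc1C(F)(F)F`: 4400 nM
compound 2 `Cc1ccccc1C(=O)Nc1ccc2c(c1)B(O)OC2`: > 100000 nM (a limit)
compound 3 `O=C(Nc1ccc2c(c1)B(O)OC2)c1ccccc1-c1ccccc1`: > 100000 nM (a limit)

Compound 1 alone carries an actual number; the other two compounds sit at the limit of > 100000 nM in this assay, at which 2 of the 3 values shown sit. Compound 4 `O=C(Nc1ccc2c(c1)B(O)OC2)c1c(F)cccc1C(F)(F)F` keeps the trifluoromethyl group of compound 1 and differs by fluoro in place of hydrogen on an aromatic carbon. The nearest evidence is an at least 22-fold higher number from compound 1 to compound 2 (1.35 log units; beyond the scatter) and an at least 22-fold higher number from compound 1 to compound 3 (1.35 log units; beyond the scatter), both large and beyond the scatter. Both replace the trifluoromethyl group, which compound 4 retains, and neither tests the hydrogen exchanged here. No step beyond the scatter is expected in this assay, and no firm direction. The expected change is a 1.3-fold lower number from compound 1 to compound 4 (0.10 log units; within the scatter). Compound 4 is estimated at 3500 nM, with an expected range of 900 nM to 14000 nM.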

Compound 4, half-maximal inhibitory concentration: 370 nM
Estimate against measurement, compound 4: 9.5-fold (0.98 log units) above; the whole stated range lies above it.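

The earlier compounds shown here changed only the trifluoromethyl group; compound 4 keeps it and shows that a second place on the same aromatic ring also matters. In this assay, fluoro in place of hydrogen, ortho to a large group and meta to a trifluoromethyl group, gives a 12-fold lower number from compound 1 to compound 4 (1.08 log units; beyond the scatter). A single added fluorine atom is therefore enough for a large step towards stronger inhibition.

From the compounds shown here alone, whether this gain depends on the trifluoromethyl group stays open. So does the outcome with chloro, methoxy or nitrile at the same place.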